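Adding a methyl to the anilino group of compound 1

The compounds below may be only part of what the source reports. "The series", "measured", "known", "first", "only" and "open" are said of these compounds alone.

Compound 1 `CN1CCN(c2ccc(/C=C3/SC(Nc4ccccc4)=NC3=O)cc2)CC1`: 0.35 ug/mL
Compound 2 `O=C1N=C(Nc2ccccc2)S/C1=C/c1ccc(N2CCNCC2)cc1`: 1.68 ug/mL
Compound 3 `CN1CCN(c2ccc(/C=C3/SC(Nc4ccc(Oc5ccccc5)cc4)=NC3=O)cc2)CC1`: 0.1 ug/mL

In a physicochemical assay (Homo sapiens) for solubility, with a stated time of 18 h, at pH 7.4 (a lower number here means a less soluble compound, a higher number a more soluble compound), compound 1 gives 0.35 ug/mL, which places it in the middle of the three measured compounds, with compound 2 higher and compound 3 lower. The next compound, compound 4 `Cc1ccccc1NC1=NC(=O)/C(=C\c2ccc(N3CCN(C)CC3)cc2)S1`, has not yet been measured. It differs from compound 1 by one change, methyl in place of hydrogen on an aromatic carbon, which turns phenyl into 2-methylphenyl.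

The closest guide is a 3.5-fold lower number from compound 1 to compound 3 (0.54 log units; beyond the scatter), where phenoxy replaces hydrogen on an aromatic carbon. Methyl is a smaller group than phenoxy, so a smaller step is expected here, possibly downward and possibly no larger than the scatter. The other step, a 4.8-fold higher number from compound 1 to compound 2 (0.68 log units; beyond the scatter), involves a methyl on an amine nitrogen in a ring, a different kind of place, and says little about this change. The expected step is a 1.3-fold lower number from compound 1 to compound 4 (0.10 log units; within the scatter). Compound 4 is estimated at 0.28 ug/mL, with an expected range from 0.1 ug/mL to 0.75 ug/mL.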

Compound 4, solubility: 0.89 ug/mL
Beside the measured number, compound 4's estimate is 3.2-fold (0.50 log units) below it; measured number above the stated range.
By their numbers in this assay, from the lowest: compound 3; then compound 1; then compounds 4 and 2 (each within the scatter of the next).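

In this assay there is a 2.5-fold higher number from compound 1 to compound 4 (0.41 log units; beyond the scatter) when a single methyl is placed on the phenyl ring of the anilino group, ortho to a large group. So adding to this ring does not always lower the number: phenoxy on the same ring gave a 3.5-fold lower number from compound 1 to compound 3 (0.54 log units; beyond the scatter) and methyl went the other way, which means the direction of the step depends on the group that enters, at least across these two changes. Nothing measured here explains the rise.

Going by these compounds, whether a methoxy, an ethyl or an amine at this place would continue the upward step or reverse it remains open. On these data alone, it is also open whether the methyl would give a similar step in compound 2, which has hydrogen in place of methyl on the amine nitrogen in the ring.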